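Removing the 2-Hydroxyethyl Group from Compound 3

The source may report more compounds than this note shows. Statements on the series, on what has been measured and on what is new or still open speak of the compounds shown alone.

Of the compounds shown here, three sharing one core have been measured in an ADME assay on MT4 cells (Homo sapiens) for cytotoxicity, read by MTT assay, with a stated time of 4 days; a lower number here means that less compound is tolerated, a higher number that more compound is tolerated. There, compound 1 `COC(=O)c1[nH]cc(C(=O)NCc2ccc(F)cc2)c(=O)c1O` gives 19000 nM and compound 2 `COCCNC(=O)c1[nH]cc(C(=O)NCc2ccc(F)cc2)c(=O)c1O` gives 16000 nM. The step separating them is a 1.2-fold lower number from compound 1 to compound 2 (0.07 log units; within the scatter). Compound 3 `O=C(NCCO)c1[nH]cc(C(=O)NCc2ccc(F)cc2)c(=O)c1O` gives > 200000 nM, which is a limit of the assay and not a number. Going by these compounds, its exact place on the scale therefore remains unknown.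

Compound 4 `NC(=O)c1[nH]cc(C(=O)NCc2ccc(F)cc2)c(=O)c1O` differs from it by one change: hydrogen in place of 2-hydroxyethyl on an amide-type nitrogen. Among the compounds with values here, two measured steps bear on this change, an at least 10-fold higher number from compound 1 to compound 3 (1.02 log units; beyond the scatter) and an at least 12-fold higher number from compound 2 to compound 3 (1.09 log units; beyond the scatter). Both are large, and both arrive at the (2-hydroxyethyl)amino group that compound 4 lacks. Neither removes that group directly, so they guide the direction better than the size. Part of that rise is expected to be lost, and the expected change is an at least 3.3-fold lower number from compound 3 to compound 4 (0.52 log units; beyond the scatter). Compound 4 is estimated at 60000 nM, with an expected range from 15000 nM to 200000 nM.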

Compound 4, half-maximal cytotoxic concentration: 40000 nM
The estimate for compound 4 lay 1.5-fold (0.18 log units) above the measured number; measured number inside the range.
By their numbers in this assay, from the lowest: compounds 2 and 1 (each within the scatter of the next); then compound 4. At a limit, above all of these: compound 3.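

In this assay, taking the 2-hydroxyethyl group off the amide-type nitrogen gives an at least 5.0-fold lower number from compound 3 to compound 4 (0.69 log units; beyond the scatter), so the plain amino group alone does not reach the level of the hydroxyethyl amide. Compound 4 still stands apart from the other two neighbours, with a 2.5-fold higher number from compound 2 to compound 4 (0.40 log units; beyond the scatter) and a 2.1-fold higher number from compound 1 to compound 4 (0.32 log units; beyond the scatter), so a modest part of the rise remains without any chain on that nitrogen. The step from compound 3 is only a floor, since compound 3 sits at a limit of the assay and not at a number: the limit of > 200000 nM in this assay, at which 1 of the 4 values shown sits.

Going by these compounds, how far compound 3 lies beyond that limit stays open, and with it the full size of the step. Also open, on these data alone, is whether a longer chain such as 3-hydroxypropyl, or a 2-aminoethyl group, on the same nitrogen would keep the number as high.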